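A Chloro Group Added to an Inactive Compound

The compounds below may be only part of what the source reports. "The series", "measured", "known", "first", "only" and "open" are said of these compounds alone.

Compound 1 and compound 2 have so far been tested in a functional assay on HO8910 cells (Homo sapiens) for inhibition, read by MTT assay, with a stated time of 24 h, tested at 100 ug/mL; a lower number here means less inhibition of growth, a higher number more inhibition of growth at the concentration tested. There, compound 1 `O=C(O)CCCCC(CCSC(=O)c1ccccc1)SC(=O)c1ccccc1` gives 86.7%. Compound 2 `O=C(CCCCC(CCSC(=O)c1ccccc1)SC(=O)c1ccccc1)Nc1ccccc1` is reported as "not active" (no number reported). No number was given for compound 2, so its exact distance from compound 1 cannot be stated.

Compound 3 `O=C(CCCCC(CCSC(=O)c1ccccc1)SC(=O)c1ccccc1)Nc1ccccc1Cl` has not yet been measured. Its structure follows that of compound 2 with a single change: chloro in place of hydrogen on an aromatic carbon. This places chloro in place of hydrogen on an aromatic carbon, ortho to a large group, turning phenyl into 2-chlorophenyl. For the measured compounds named here, no measured pair here shows what such a change does, so any forecast remains rough.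

Since compound 2 is reported as "not active" (no number reported), a small upward step in this assay is expected, or none beyond the usual scatter. A larger rise cannot be ruled out, but a return to the level of compound 1 seems unlikely. The estimate for compound 3 is 20%, expected to lie between 0% and 55%.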

Compound 3, percent growth inhibition at one concentration: "not active" (no number reported)
Nothing numeric was reported for compound 3; the estimate stays without a comparison.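

For the compounds shown here, compound 3 gives "not active" (no number reported) in this assay, and compound 2 likewise carries no number there, so no step between the two can be read. Nothing available bears on why this result came out as it did.
The compounds shown leave open whether 2-chlorophenyl in place of phenyl shifts growth inhibition at all, and how far either compound stands from compound 1.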